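This account rests on a few compounds, and the source may have more. Where it says the series, first, only, none or still open, it means among the compounds named here.

Compound 2 `COc1cc(N(Cc2nc3ccccc3[nH]2)S(=O)(=O)c2ccccc2)cc(OC)c1OC` gives 25500 nM in a functional assay on PC-3 cells (Homo sapiens) for inhibition, read by MTT assay, with a stated time of 48 h; on this read-out higher numbers stand for weaker inhibition and lower numbers for stronger inhibition. Compound 3 `Cc1ccc(N(Cc2nc3ccccc3[nH]2)S(=O)(=O)c2ccc(C)cc2)cc1` gives 48900 nM in this assay, a number within the scatter of that of compound 2. Compound 1 `COc1ccc(CN(c2cc(OC)c(OC)c(OC)c2)S(=O)(=O)c2ccccc2)cc1` is reported in this assay only as a limit, > 50000 nM. The one measured step that joins two of these compounds is an at least 1.9-fold lower number from compound 1 to compound 2 (0.29 log units; that floor lies within the scatter), and it touches the group on the saturated chain carbon, not the group on the sulfonamide nitrogen. Compound 4 `COc1cc(N(Cc2nc3ccccc3[nH]2)C(=O)c2ccc(F)cc2)cc(OC)c1OC` differs from compound 2 at that nitrogen: (4-fluorophenyl)carbonyl in place of phenylsulfonyl on a nitrogen on an aromatic ring. No measured step bears on an exchange at this position, and the one step shown is itself within the scatter, with compound 1 sitting at the limit of the limit of > 50000 nM in this assay, at which 1 of the 3 values shown sits. Without a measured step to rest on, the expectation is a step of no clear size beyond the scatter, so that compound 2 to compound 4 is estimated as a 1.0-fold lower number from compound 2 to compound 4 (0.01 log units; within the scatter). Compound 4 is therefore expected to give about 25000 nM, with a range from 8000 nM to 80000 nM, in this assay.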

Compound 4, half-maximal inhibitory concentration: 21900 nM
For compound 4 the middle estimate is 1.1-fold (0.06 log units) above the measured one, within the range that was stated.
By their numbers in this assay, from the lowest: compounds 4, 2 and 3 (each within the scatter of the next, the first and the last beyond it). At a limit, above all of these: compound 1.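

The exchange of phenylsulfonyl for (4-fluorophenyl)carbonyl on the nitrogen now has a measured size in this assay, and it is a 1.2-fold lower number from compound 2 to compound 4 (0.07 log units; within the scatter). At this position, then, a carbonyl link serves as well as a sulfonyl link in this assay, even with one hydrogen-bond acceptor in place of two and the same count of heavy atoms in the group. Compound 2 and compound 4 are both read as numbers, so this step has no floor, unlike the earlier step from compound 1, whose value is only a limit: the limit of > 50000 nM in this assay, at which 1 of the 4 values shown sits.

The change swaps the link and adds the fluorine at once, and the compounds shown do not separate the two. From the compounds shown here alone, how a plain phenylcarbonyl, an acetyl group or a bare hydrogen on this nitrogen would read remains open.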